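The source may hold more compounds than are shown below. What is called first, only, known or untested is meant among the compounds shown, and "the series" means these compounds.

Measured so far:
- compound 1 `N#CN/C(=N\C1CCCCCCC1)Nc1ccncc1`: in a functional assay on the whole organism (blood, strain Wistar-Okamoto) with Rattus norvegicus as the target, with a stated time of 5 days (a higher number here means that more compound is needed for the effect, a lower number that less compound is needed), compound 1 gives > 20 mg/kg, which is a limit of the assay and not a number.
- compound 2 `CCC(C)(C)N/C(=N\C#N)NCc1ccncc1`: in this assay compound 2 gives 20 mg/kg.
- compound 3 `CC(N/C(=N\C#N)NCc1ccncc1)C(C)(C)C`: in this assay compound 3 gives 20 mg/kg.

Within the data shown here, compound 2 stands level with compound 3; the only computed step, no change at the digits printed from compound 2 to compound 3 (within the scatter), lies within the scatter, and the remaining value of the set is the limit noted for compound 1 (the limit of > 20 mg/kg in this assay, at which 1 of the 3 values shown sits).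

Compound 4 `CCC(C)(C)N/C(=N\C#N)NCCCN(C)C` is not yet measured. It differs from compound 2 in one place: 2-(dimethylamino)ethyl in place of pyridin-4-yl on a saturated chain carbon bound to an amine nitrogen.

Among the measured compounds shown here, no measured step touches this part of the molecule. The step from compound 2 to compound 3 changes the group on the other amine nitrogen and shows no change; it therefore gives no direction for the present change, and compound 1 supplies only a limit. With no bearing evidence, no step beyond the scatter is expected in this assay in either direction, though the range must stay wide.

Compound 4 is expected to give about 20 mg/kg, between 7 mg/kg and 60 mg/kg, so that the estimated step of no change at the digits printed from compound 2 to compound 4 (within the scatter) is essentially flat.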

Compound 4, minimum effective dose: 25 mg/kg
For compound 4 the middle estimate is 1.3-fold (0.10 log units) below the measured one; low and high end bracket the measured number.
By their numbers in this assay, from the lowest: compounds 2, 3 and 4 (each within the scatter of the next).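

In this assay, among these compounds, the first change at this place, on a saturated chain carbon bound to an amine nitrogen, gives a 1.3-fold higher number from compound 2 to compound 4 (0.10 log units; within the scatter). The pyridin-4-yl ring is therefore not needed to hold the level of compound 2, since 2-(dimethylamino)ethyl, which has no ring, serves equally well in this pair. Nothing to hand explains why the two groups read alike.

From the compounds shown here alone, this rests on a single pair, so it remains open whether the same exchange would read the same way with the 1,2,2-trimethylpropyl group of compound 3 on the other amine nitrogen. Also open, going by these compounds, is what a carboxylic acid, a plain phenyl ring or a longer chain carrying the dimethylamino group would do at this place.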